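This account rests on a few compounds, and the source may have more. Where it says the series, first, only, none or still open, it means among the compounds named here.

Measured compounds:
Compound 1, `CN(C)c1ccc(/C=C(/SCc2ccc(Cl)cc2Cl)C(=O)c2ccc(Cl)cc2)cc1`: 50000 nM
Compound 2, `CN(C)c1ccc(/C=C(/Sc2ccc(Br)cc2)C(=O)c2ccc(Cl)cc2)cc1`: reported only as a limit, > 100000 nM
Compound 3, `CN(C)c1ccc(/C=C(/SCc2ccc(F)cc2)C(=O)c2ccc(Cl)cc2)cc1`: 50000 nM

All three were tested in a functional assay on DU-145 cells (Homo sapiens) for inhibition, read by trypan blue exclusion, with a stated time of 96 h; on this read-out lower numbers stand for stronger inhibition of growth and higher numbers for weaker inhibition of growth. Compound 1 and compound 3 each gave a number, whereas compound 2 stands at a limit of the assay and no number is known for it; the limit is the limit of > 100000 nM in this assay, at which 1 of the 3 values shown sits. The two measured steps that touch compound 2 both change the group on the sulfur: an at least 2.0-fold higher number from compound 1 to compound 2 (0.30 log units; that floor lies within the scatter), and an at least 2.0-fold lower number from compound 2 to compound 3 (0.30 log units; that floor lies within the scatter). Neither reaches beyond the scatter, so on the numbers shown compound 2 is at least as weak as compound 1 and compound 3, and possibly much weaker.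

Compound 4, `COc1ccccc1/C=C(/Sc1ccc(Br)cc1)C(=O)c1ccc(Cl)cc1`, differs from compound 2 elsewhere: 2-methoxyphenyl in place of 4-(dimethylamino)phenyl on a double-bonded chain carbon bound to a double-bonded chain carbon. For the measured compounds named here, none of the measured steps alters this part of the shared core, so there is no step that bears on the change; the group on the sulfur stays the same as in compound 2. With no guidance either way, the expected step is about none beyond the scatter, which is what a number no higher from compound 2 to compound 4 (the limit leaves the size open) expresses as an estimate. Compound 4 is therefore expected to give roughly 100000 nM in this assay, with a range from 30000 nM to 300000 nM, and it may well again be reported only as a limit.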

Compound 4, concentration for 50% growth inhibition: 10000 nM
Estimate against measurement, compound 4: 10-fold (1.00 log units) above, outside the stated range (below it).
By their numbers in this assay, from the lowest: compound 4; then compounds 1 and 3 (each within the scatter of the next). At a limit, above all of these: compound 2.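

Every earlier step changed the group on the sulfur, and none was shown to reach beyond the scatter. Exchanging 4-(dimethylamino)phenyl for 2-methoxyphenyl, with the 4-bromophenyl group on the sulfur kept in place, gives an at least 10-fold lower number from compound 2 to compound 4 (1.00 log units; beyond the scatter), so in this assay this position can clearly change how strongly growth is inhibited. That size is only a floor, and the full step could be larger, as compound 2 is known only through a limit: the limit of > 100000 nM in this assay, at which 1 of the 4 values shown sits.

The swap removes one substituted ring and brings in another, so the compounds shown cannot tell whether the step comes from losing the dimethylamino group, gaining the methoxy group, or both, and a plain phenyl group or a pyridine ring at this position would help to separate these cases. As far as these compounds go, it also remains open whether 2-methoxyphenyl would give a similar step with the 2,4-dichlorobenzyl group of compound 1 or the 4-fluorobenzyl group of compound 3 on the sulfur.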